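The source may hold more compounds than are shown below. What is called first, only, known or untested is meant among the compounds shown, and "the series" means these compounds.

For the measured compounds named here, in an ADME assay on a cell-free system (plasma, Rattus norvegicus, strain Wistar Han) for pharmacokinetics, at a dose of 2 umol/kg (on this read-out lower numbers stand for slow clearance and higher numbers for fast clearance), three compounds have numbers so far. Compound 1 (`COc1cc(N2CCN(C)CC2)ccc1Nc1nccc(-c2cn(C)c3c(C)nccc23)n1`) gives 24 mL/min/kg and compound 3 (`Cn1cc(-c2ccnc(-c3ccc(S(C)(=O)=O)cc3)n2)c2ccncc21`) gives 23 mL/min/kg, so these two stand level within the scatter. Compound 2 (`COc1cc(N2CCN(C(C)=O)CC2)ccc1Nc1cc(-c2c[nH]c3cnccc23)ncn1`) gives 239 mL/min/kg, well apart from both. The next compound to be read is compound 4 (`COc1cc(N2CCN(C)CC2)ccc1Nc1nccc(-c2c[nH]c3c(C)nccc23)n1`), which differs from compound 1 in one place: hydrogen in place of methyl on an aromatic nitrogen. Going by the values given here, no measured pair isolates this change, so the data offer no direct size for it. Among the compounds with values here, the only hint is compound 2, which also carries hydrogen on such a nitrogen and gives 239 mL/min/kg, but it differs from compound 1 elsewhere as well, which makes it weak evidence. A modest upward move in this assay, close to the scatter, is therefore expected, estimated as a 1.7-fold higher number from compound 1 to compound 4 (0.22 log units; within the scatter). For compound 4 the expected clearance is 40 mL/min/kg, with an estimated range from 18 mL/min/kg to 100 mL/min/kg.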

Compound 4, clearance: 38 mL/min/kg
Estimate against measurement, compound 4: 1.1-fold (0.02 log units) above; measured number inside the range.
By their numbers in this assay, from the lowest: compounds 3, 1 and 4 (each within the scatter of the next); then compound 2.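

In this assay, for the compounds shown here, the first pair to isolate this change shows a 1.6-fold higher number from compound 1 to compound 4 (0.20 log units; within the scatter), so with the rest of compound 1 held fixed, hydrogen in place of methyl on this aromatic nitrogen gives no shift that can be told from the scatter. The position of the five-membered aromatic ring therefore accepts either group without a clear change in the read-out, and the hydrogen on this nitrogen cannot by itself be linked to the far larger number of compound 2, which differs in other places as well. Nothing measured here speaks to the cause of this small step.

From the compounds shown here alone, whether an ethyl group, a longer chain or a chain ending in an amine on this nitrogen would stay level with compound 1 remains open. So does whether the same change would stay within the scatter on a different core.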